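Methoxy in place of trifluoromethyl: working notes on compound 4

A few compounds are considered here, and "the series" means these few. Any claim that something is new, unique, unknown or untested is made for them only; others in the source may bear on it.

The series shares one core, seen in compound 1 (`COC(=O)CNC(=O)c1ccc(-n2ncc3c(N)ncnc32)cc1`), compound 2 (`Nc1ncnc2c1cnn2-c1ccc(C(=O)O)cc1`), compound 3 (`Nc1ncnc2c1cnn2-c1ccc(C(F)(F)F)cc1`) and compound 4 (`COc1ccc(-n2ncc3c(N)ncnc32)cc1`). In a functional assay on MCF7 cells (Homo sapiens) for inhibition, with a stated time of 48 h (on this read-out higher numbers stand for weaker inhibition of growth and lower numbers for stronger inhibition of growth), compound 1 gives > 150000 nM, which is a limit of the assay and not a number. Compound 2 has the entry "not determined" (no result reported). Compound 3 has no single number, and its entry reads "not determined" (no result reported), so the starting point of this step is open.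

The change is methoxy in place of trifluoromethyl on an aromatic carbon, para to a large group. Within the data shown here, no measured step gives a size for this exchange. In this assay no step beyond the scatter is expected in either direction, and growth inhibition is expected to remain weak. Compound 1, the only anchor for that expectation, stands at > 150000 nM, again a limit of the assay. Compound 4 is estimated at 80000 nM, with an expected range from 15000 nM to 200000 nM.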

Compound 4, concentration for 50% growth inhibition: > 150000 nM
Compound 4 was reported as a limit; the forecaster's own chance of this, stated with the estimate: 50%; middle value at least 1.8-fold (0.27 log units) away from the limit.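

No new step can be read between compound 1 and compound 4, since both stand at a limit of the assay and not at a number: the limit of > 150000 nM in this assay, at which 2 of the 4 values shown sit.

The compounds shown leave open what size the exchange of trifluoromethyl for methoxy has in this assay.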